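Adding a methyl to the ring nitrogen of compound 3

The compounds below may be only part of what the source reports. "The series", "measured", "known", "first", "only" and "open" are said of these compounds alone.

Compound 3, with structure `CCn1cc(-c2nc3ccc([N+](=O)[O-])cc3[nH]2)c(=O)c2cc(F)c(N3CCNCC3)cc21`, is one of two compounds here that give a number in a functional assay on A2780 cells (Homo sapiens) for cytotoxicity, read by MTT assay, with a stated time of 48 h; a lower number here means a stronger inhibitor, a higher number a weaker inhibitor. In this assay compound 3 gives 1600 nM, and compound 1, with structure `CCn1cc(-c2nc3ccccc3[nH]2)c(=O)c2cc(F)c(N3CCNCC3)cc21`, gives 800 nM. The gap between them, a 2.0-fold higher number from compound 1 to compound 3 (0.30 log units; within the scatter), is the only difference a nitro in place of hydrogen on an aromatic carbon makes here. Compound 2, with structure `CCn1cc(-c2nc3ccccc3[nH]2)c(=O)c2cc(F)c(N3CCN(C)CC3)cc21`, gives only a limit in this assay, > 5010000 nM.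

Compound 4, with structure `CCn1cc(-c2nc3ccc([N+](=O)[O-])cc3[nH]2)c(=O)c2cc(F)c(N3CCN(C)CC3)cc21`, differs from compound 3 by methyl in place of hydrogen on an amine nitrogen in a ring. The same change, made on compound 1, gave an at least 6200-fold higher number from compound 1 to compound 2 (3.79 log units; beyond the scatter), a very large loss of potency that ends at the limit of the assay (the limit of > 5010000 nM in this assay, at which 1 of the 3 values shown sits). Since compound 3 and compound 1 are within the scatter of each other, the same large loss is expected in this assay for compound 4, namely a 6300-fold higher number from compound 3 to compound 4 (3.80 log units; beyond the scatter). Compound 4 is therefore estimated at 10000000 nM, with a range from 500000 nM to 100000000 nM, and most likely the assay will again report only a limit.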

Compound 4, half-maximal inhibitory concentration: 4700 nM
Beside the measured number, compound 4's estimate is 2100-fold (3.33 log units) above it; measured number outside the range, below it.
By their numbers in this assay, from the lowest: compounds 1 and 3 (each within the scatter of the next); then compound 4. At a limit, above all of these: compound 2.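

In this assay, the effect of methyl in place of hydrogen on an amine nitrogen in a ring depends on the rest of the molecule. With the nitro group present, the change from piperazin-1-yl to 4-methylpiperazin-1-yl gives only a 2.9-fold higher number from compound 3 to compound 4 (0.47 log units; beyond the scatter), so the large loss seen without nitro does not carry over: the same change on two cores in this assay, an at least 6200-fold higher number (3.79 log units; beyond the scatter) from compound 1 to compound 2 and a 2.9-fold higher number (0.47 log units; beyond the scatter) from compound 3 to compound 4, at least 2100-fold (3.32 log units) apart, beyond the scatter of two such steps. Read the other way, nitro in place of hydrogen on an aromatic carbon gives an at least 1000-fold lower number from compound 2 to compound 4 (3.02 log units; beyond the scatter) once the methyl is present, although it made no difference beyond the scatter without the methyl: the same change on two cores in this assay, a 2.0-fold higher number (0.30 log units; within the scatter) from compound 1 to compound 3 and an at least 1000-fold lower number (3.02 log units; beyond the scatter) from compound 2 to compound 4, at least 2100-fold (3.32 log units) apart, beyond the scatter of two such steps.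

The compounds shown do not tell whether this dependence is specific to nitro or would also appear with an amine or a carboxylic acid at that carbon. They also leave open how a longer chain, such as propyl, would behave on the amine nitrogen.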